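The source may hold more compounds than are shown below. What is called first, only, known or untested is meant among the compounds shown, and "the series" means these compounds.

Compound 1 `CCCOc1cc([N+](=O)[O-])ccc1NS(C)(=O)=O` was tested in an assay on SK-BR-3 cells for inhibition of Aromatase (Homo sapiens) (a higher number here means a weaker inhibitor, a lower number a stronger inhibitor), where compound 1 gives 2510 nM. Compound 2 `CC(C)Oc1cc([N+](=O)[O-])ccc1NS(C)(=O)=O` carries one change, (isopropyl in place of propyl on an oxygen on an aromatic ring), and in this assay compound 2 gives 5870 nM; that is a 2.3-fold higher number from compound 1 to compound 2 (0.37 log units; beyond the scatter). Compound 3 `CCCOc1cc([N+](=O)[O-])ccc1N(C)S(C)(=O)=O` differs from compound 1 by methyl in place of hydrogen on a sulfonamide nitrogen, and in this assay compound 3 gives 760 nM, which is a 3.3-fold lower number from compound 1 to compound 3 (0.52 log units; beyond the scatter), the lowest number among the three measured compounds.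

Compound 4 `CC(C)Oc1cc([N+](=O)[O-])ccc1N(C)S(C)(=O)=O` has not yet been measured. It differs from compound 3 by isopropyl in place of propyl on an oxygen on an aromatic ring, the same change that was made from compound 1 to compound 2, since the two place descriptions agree word for word; the cores of the two pairs differ by methyl in place of hydrogen on a sulfonamide nitrogen. Because the earlier step was a 2.3-fold higher number from compound 1 to compound 2 (0.37 log units; beyond the scatter), a step of similar size is expected here, so that compound 4 is expected to show a 2.2-fold higher number from compound 3 to compound 4 (0.35 log units; beyond the scatter). On that basis, compound 4 is estimated at 1700 nM in this assay, with a likely range from 900 nM to 3500 nM, resting on a single earlier example of this change.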

Compound 4, half-maximal inhibitory concentration: 2810 nM
Compound 4: middle estimate off by 1.7-fold (0.22 log units), on the low side; the range from low to high includes it.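

In this assay, isopropyl in place of propyl on the oxygen gives a 3.7-fold higher number from compound 3 to compound 4 (0.57 log units; beyond the scatter), the same direction as on the core of compound 1, and the two steps agree in size: the same change on two cores in this assay, a 2.3-fold higher number (0.37 log units; beyond the scatter) from compound 1 to compound 2 and a 3.7-fold higher number (0.57 log units; beyond the scatter) from compound 3 to compound 4, 1.6-fold (0.20 log units) apart, within the scatter of two such steps Methyl in place of hydrogen on the sulfonamide nitrogen likewise gives a 2.1-fold lower number from compound 2 to compound 4 (0.32 log units; beyond the scatter), and it too carries over between the two cores in direction and size: the same change on two cores in this assay, a 3.3-fold lower number (0.52 log units; beyond the scatter) from compound 1 to compound 3 and a 2.1-fold lower number (0.32 log units; beyond the scatter) from compound 2 to compound 4, 1.6-fold (0.20 log units) apart, within the scatter of two such steps These four compounds show that each change behaved alike on the two cores tested here, but they do not show that either change would carry over to a core that differs elsewhere, nor do they explain why the numbers move.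

The compounds shown leave open how a longer chain such as butyl, or a cyclopropylmethyl group, would fare on the oxygen. They also leave open what an ethyl group on the sulfonamide nitrogen, or an amine or a nitrile in place of the nitro group, would do.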